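The source may hold more compounds than are shown below. What is called first, only, known or untested is meant among the compounds shown, and "the series" means these compounds.

Among the measured compounds shown here, compound 1 `CCCCCCC(C#CC(=O)OC)O/C=C/C(=O)OC` is one of two compounds so far measured in a functional assay on SW1573 cells (Homo sapiens) for antiproliferative activity, read by sulforhodamine B assay, with a stated time of 48 h; on this read-out higher numbers stand for weaker inhibition of growth and lower numbers for stronger inhibition of growth. In this assay compound 1 gives 3300 nM, the highest of the two numbers. The nearest compound is compound 2 `COC(=O)C#CC(CCc1ccccc1)O/C=C/C(=O)OC`, which in this assay gives 2600 nM. The step of a 1.3-fold lower number from compound 1 to compound 2 (0.10 log units; within the scatter) lies within the scatter, so the two numbers cannot be told apart. Compound 3 `COC(=O)C#CC(O/C=C/C(=O)OC)C(C)C` has not yet been measured. It differs from compound 1 in one place: isopropyl in place of hexyl on a saturated chain carbon bound to an oxygen on an unsaturated carbon and a triple-bonded carbon. For the measured compounds named here, the only measured step that bears on this change is a 1.3-fold lower number from compound 1 to compound 2 (0.10 log units; within the scatter), which swapped one group for another on the same saturated chain and produced no difference beyond the scatter. Going by the values given here, with that single comparison as the only guide, the change in compound 3 is expected to move the number in this assay by no more than the scatter, with no direction favoured. Compound 3 is therefore expected to give 3300 nM, within a range from 1500 nM to 7500 nM. This estimate means an expected step of no change at the digits printed from compound 1 to compound 3 (within the scatter).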

Compound 3, concentration for 50% growth inhibition: 750 nM
Compound 3: the middle estimate sits 4.4-fold (0.64 log units) above what was measured; the whole stated range lies above it.
By their numbers in this assay, from the lowest: compound 3; then compounds 2 and 1 (each within the scatter of the next).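

On the saturated chain carbon bound to an oxygen on an unsaturated carbon and a triple-bonded carbon, the group can change the result in this assay: the step is a 4.4-fold lower number from compound 1 to compound 3 (0.64 log units; beyond the scatter) and it lies beyond the scatter. The earlier swap on this chain, a 1.3-fold lower number from compound 1 to compound 2 (0.10 log units; within the scatter), could not be told apart from no change, so that comparison alone made the chain look indifferent to what it carries; this new step shows that it is not, and that replacing hexyl, with 6 heavy atoms, by isopropyl, with 3, gives stronger inhibition of growth. Nothing available explains why this swap moves the number.

The compounds shown leave open whether the lower number goes with the smaller carbon count or with the forked shape of isopropyl, and a straight propyl chain in the same place would separate those two readings. Also open, on these data alone, is whether the number keeps falling with a still smaller group such as methyl, and how a ring such as cyclohexyl or a chain bearing an amine would compare.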